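Replacing the 2,3-dihydroxypropyl Group of Compound 3

This account rests on a few compounds, and the source may have more. Where it says the series, first, only, none or still open, it means among the compounds named here.

In a functional assay on MCF7 cells (Homo sapiens) for cytotoxicity, read by MTT assay, with a stated time of 72 h (a lower number here means a stronger inhibitor, a higher number a weaker inhibitor), compound 1 `O=C1c2c[n+]([O-])c3ccccc3c2C(=O)c2c1c1ccccc1n2Cc1cn([C@H]2O[C@H](CO)[C@@H](O)[C@H]2O)nn1` gives 1490 nM and compound 2 `O=C1c2c[n+]([O-])c3ccccc3c2C(=O)c2c1c1ccccc1n2Cc1cn([C@@H]2C[C@H](O)[C@@H](CO)O2)nn1` gives 110 nM. Compound 3 `O=C1c2c[n+]([O-])c3ccccc3c2C(=O)c2c1c1ccccc1n2Cc1cn(C[C@H](O)CO)nn1` gives > 1000 nM, which is a limit and not a number. Compound 4 `CC1(C)OCC(Cn2cc(Cn3c4c(c5ccccc53)C(=O)c3c[n+]([O-])c5ccccc5c3C4=O)nn2)O1` carries 2,2-dimethyl-1,3-dioxolan-4-yl in place of 1,2-dihydroxyethyl on a saturated chain carbon bound to an aromatic nitrogen. The closest guide is hydrogen in place of hydroxy on a saturated ring carbon, which gave a 14-fold lower number from compound 1 to compound 2 (1.13 log units; beyond the scatter). The sugar-to-chain change gave an at least 9.0-fold higher number from compound 2 to compound 3 (0.95 log units; beyond the scatter). Hydrogen-bond donors are lost here too, so a moderately lower number is expected in this assay, with the expected step being an at least 2.0-fold lower number from compound 3 to compound 4 (0.30 log units; that floor lies within the scatter). For compound 4 the estimated value is 500 nM, with an expected range from 120 nM to 2000 nM.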

Compound 4, half-maximal inhibitory concentration: 290 nM
For compound 4 the middle estimate is 1.7-fold (0.24 log units) above the measured one; the measured number falls inside the stated range.
By their numbers in this assay, from the lowest: compound 2; then compound 4; then compound 1.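

In this assay, replacing 1,2-dihydroxyethyl with 2,2-dimethyl-1,3-dioxolan-4-yl gives an at least 3.4-fold lower number from compound 3 to compound 4 (0.53 log units; beyond the scatter), so a side chain with 0 hydrogen-bond donors at this place keeps activity. That step starts from a limit and not a number: the limit of > 1000 nM in this assay, at which 1 of the 4 values shown sits. Against the sugar-bearing compounds, (2,2-dimethyl-1,3-dioxolan-4-yl)methyl gives a 5.1-fold lower number from compound 1 to compound 4 (0.71 log units; beyond the scatter) and a 2.6-fold higher number from compound 2 to compound 4 (0.42 log units; beyond the scatter), so a non-sugar group surpasses one sugar but not the other.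

The compounds shown do not separate the effect of the new ring from that of losing the hydroxy groups. They also leave open how an amine or a carboxylic acid on this chain would compare.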